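This account rests on a few compounds, and the source may have more. Where it says the series, first, only, none or still open, it means among the compounds named here.

Of the compounds shown here, two with a shared core have been measured so far. Compound 1 `CCCCN(CCC)c1nc(C)nc2c(-c3c(C)cc(N(C)C)nc3C)c(C)nn12` gives 12.8 nM in an assay on cell membranes for displacement of a labelled ligand from corticotropin-releasing factor receptor 1 (Rattus norvegicus); a lower number here means a stronger inhibitor, a higher number a weaker inhibitor. Compound 2 `CCC(CC)Nc1nc(C)nc2c(-c3c(C)cc(N(C)C)nc3C)c(C)nn12` carries a (pentan-3-yl)amino group where compound 1 carries a butyl(propyl)amino group. In this assay compound 2 gives 25.6 nM. Among the measured compounds shown here, that single step, a 2.0-fold higher number from compound 1 to compound 2 (0.30 log units; within the scatter), is the only comparison available, and it leaves compound 2 with the higher of the two numbers, though the gap is not one that can be trusted.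

Compound 3 `CCC(CC)Nc1nc(C)nc2c(-c3cnc(N(C)C)cc3C)c(C)nn12` differs from compound 2 at a different site: hydrogen in place of methyl on an aromatic carbon. For the measured compounds named here, no measured pair touches this part of the molecule; the one step known, a 2.0-fold higher number from compound 1 to compound 2 (0.30 log units; within the scatter), concerns the amine on the other side of the core and says nothing about removing a methyl group from the pyridine ring. With no guide from the data, the expectation for compound 3 in this assay rests only on the change itself, and a modest move toward a higher number is expected, a 2.3-fold higher number from compound 2 to compound 3 (0.37 log units; beyond the scatter), with a wide range. Compound 3 is therefore estimated at 60 nM, somewhere between 15 nM and 250 nM.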

Compound 3, half-maximal inhibitory concentration: 24.8 nM
Compound 3: middle estimate off by 2.4-fold (0.38 log units), on the high side; measured number inside the range.
By their numbers in this assay, from the lowest: compounds 1, 3 and 2 (each within the scatter of the next).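

Among the compounds shown here, the step of a 1.0-fold lower number from compound 2 to compound 3 (0.01 log units; within the scatter) is the first reading at this site, an aromatic carbon of a six-membered aromatic ring with 1 nitrogen, next to the ring nitrogen and ortho to a large group. It shows that, in this assay, a methyl group here and a bare hydrogen cannot be told apart for this pair: the heavy atom can leave without any change that rises above the usual scatter of repeated measurements. For the compounds shown here, this is one pair with one amine, the (pentan-3-yl)amino group, so it describes compound 2 and compound 3 only and sets no general rule for the series, and nothing measured so far offers a reason for the result.

The compounds shown leave open whether hydrogen and methyl would also match at this carbon when the butyl(propyl)amino group of compound 1 sits on the other side of the core. They also leave open whether this carbon would accept something other than hydrogen or methyl, such as an ethyl group, a methoxy group or a chlorine atom, with an equally small step in this read-out.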